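Swapping a formyl for a methoxy on the aryl ether

This account rests on a few compounds, and the source may have more. Where it says the series, first, only, none or still open, it means among the compounds named here.

Measured compounds:
compound 1, `CN(C)c1ccc(C(=O)Nc2cccc(NC(=O)COc3ccc4c(c3)CCC(=O)N4)c2)cc1`, 9970 nM
compound 2, `COc1cc(OCC(=O)Nc2cccc(NC(=O)c3ccc(N(C)C)cc3)c2)ccc1C=O`, 306 nM

Both numbers come from an assay on isolated protein for inhibition of Rho-associated protein kinase 2 (Homo sapiens), read by scintillation counting, radiometric assay and 33P incorporation, with a stated time of 40 min, in the presence of a further agent that is not named here; on this read-out higher numbers stand for weaker inhibition and lower numbers for stronger inhibition. Compound 2 stands at the lowest of the two numbers; its nearest neighbour is compound 1, and the step of a 33-fold lower number from compound 1 to compound 2 (1.51 log units; beyond the scatter) lies beyond the scatter, so compound 2 is the stronger inhibitor of the pair.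

Compound 3, `COc1ccc(OCC(=O)Nc2cccc(NC(=O)c3ccc(N(C)C)cc3)c2)cc1OC`, keeps the shared core of compound 2 and differs in one place: methoxy in place of formyl on an aromatic carbon. Within the data shown here, no measured step changes a single small substituent on that ring; the only step in hand, from compound 1 to compound 2, replaced the whole aryl ether portion and was large, which shows only that this region of the molecule matters. A change of a single group at the same place is expected to be smaller. The estimate for compound 3 is therefore a modest step to a somewhat higher number in this assay, a 2.0-fold higher number from compound 2 to compound 3 (0.29 log units; within the scatter), with wide uncertainty. Compound 3 is expected to give about 600 nM, within a range from 150 nM to 3000 nM.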

Compound 3, half-maximal inhibitory concentration: > 10000 nM
Compound 3 ended at the assay's limit; the forecaster's own chance of this, stated with the estimate: 5%; middle value at least 16-fold (1.22 log units) away from the limit.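

A single exchange on an aromatic carbon, formyl out and methoxy in, produces an at least 32-fold higher number from compound 2 to compound 3 (1.51 log units; beyond the scatter) in this assay, even though the two groups have the same count of heavy atoms and of hydrogen-bond acceptors. The earlier step replaced the whole aryl ether portion, so it could not show that one small group at this place, para to a large group, can decide so much of the result. The value of compound 3 is a limit of this assay and not a number, so the data give only a number no lower from compound 1 to compound 3 (the limit leaves the size open) and that step cannot be read further: the limit of > 10000 nM in this assay, at which 1 of the 3 values shown sits.

The compounds shown leave open whether formyl itself is needed at this aromatic carbon, or whether a group such as a nitrile, a hydroxymethyl or a carboxylic acid could keep a number close to that of compound 2, 306 nM. Also open, from the compounds shown here alone, is what the methoxy group shared by compound 2 and compound 3 adds, for instance whether an ethoxy group or a plain hydrogen in its place would preserve the activity seen with formyl.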